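Replacing the Dimethylaminophenyl of Compound 2 with Pyridin-4-yl

This account rests on a few compounds, and the source may have more. Where it says the series, first, only, none or still open, it means among the compounds named here.

Compound 1 `O=C(N/N=C/c1ccc(F)cc1)c1cccnc1Nc1cccc(C(F)(F)F)c1`: 41.2%
Compound 2 `CN(C)c1ccc(/C=N/NC(=O)c2cccnc2Nc2cccc(C(F)(F)F)c2)cc1`: 51.4%

In a functional assay on the whole organism (strain Wistar) for inhibition, with Rattus norvegicus as the target, read by paw edema, with a stated time of 2 h, at a dose of 10 mg/kg by the intraperitoneal route (on this read-out lower numbers stand for less inhibition and higher numbers for more inhibition at the one dose given (going by the name of the read-out)), compound 1 gives 41.2% and compound 2 gives 51.4%. For the measured compounds named here, compound 2 stands highest of the two numbers, and the single measured step, a number 10.2 percentage points higher from compound 1 to compound 2 (beyond the scatter), separates it from compound 1, which is its nearest neighbour.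

Compound 3 `O=C(N/N=C/c1ccncc1)c1cccnc1Nc1cccc(C(F)(F)F)c1` has not yet been measured. Its structural change from compound 2 is pyridin-4-yl in place of 4-(dimethylamino)phenyl on a carbon with a double bond to nitrogen. Going by the values given here, the one measured step concerns a different group at a different place, so it bears on this change only loosely: it shows that the dimethylamino group went along with the higher number, and compound 3 no longer carries that group. Among the compounds with values here, a step back toward the region of compound 1 is therefore expected, of modest size and downward, though no measured step directly supports this.

Compound 3 is expected to give 40%, with a range from 25% to 55%. This corresponds to an estimated step of a number 11.4 percentage points lower from compound 2 to compound 3 (beyond the scatter).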

Compound 3, a percentage reported as inhibition, in the whole organism at one dose (the size of the read-out at that dose, not a potency): 65.2%
For compound 3 the middle estimate is 25.2 percentage points below the measured one; the whole stated range lies below it.
By their numbers in this assay, from the lowest: compound 1; then compound 2; then compound 3.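

In this assay pyridin-4-yl in place of 4-(dimethylamino)phenyl on a carbon with a double bond to nitrogen gives a number 13.8 percentage points higher from compound 2 to compound 3 (beyond the scatter) and pyridin-4-yl in place of 4-fluorophenyl gives a number 24 percentage points higher from compound 1 to compound 3 (beyond the scatter) at this same place. The earlier step had only shown that dimethylamino stood higher than fluoro on a ring of carbon only. Compound 3 carries neither group and has a ring with a hetero atom, yet it stands highest of the three, so a high number at this position does not depend on the dimethylamino group.

The compounds shown leave open what pyridin-3-yl or pyridin-2-yl, with the ring nitrogen placed differently, or a ring of carbon only bearing a carboxylic acid, would give here. No measurement shown speaks to why compound 3 stands highest.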